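Indole 5-substituent swaps on the shared core

The source may report more compounds than this note shows. Statements on the series, on what has been measured and on what is new or still open speak of the compounds shown alone.

Compound 1 `COC(=O)[C@@]1(C)CCC=C2[C@@H]1CC[C@@H](C)[C@]2(C)Cc1c[nH]c2ccc(Br)cc12` and compound 2 `COC(=O)[C@@]1(C)CCC=C2[C@@H]1CC[C@@H](C)[C@]2(C)Cc1c[nH]c2ccc(Cl)cc12` differ only by chloro in place of bromo on an aromatic carbon. In a functional assay on T47D cells (Homo sapiens) for inhibition, read by sulforhodamine B assay, with a stated time of 48 h (on this read-out higher numbers stand for weaker inhibition of growth and lower numbers for stronger inhibition of growth), compound 1 gives 16000 nM, and compound 2 gives 17000 nM. The step of a 1.1-fold higher number from compound 1 to compound 2 (0.03 log units; within the scatter) shows that this halogen exchange leaves the read-out essentially unchanged, so compound 1 stands with the lower of the two numbers, though within the scatter of compound 2.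

Compound 3 `COC(=O)[C@@]1(C)CCC=C2[C@@H]1CC[C@@H](C)[C@]2(C)Cc1c[nH]c2ccc(C(F)(F)F)cc12` is not yet measured. It differs from compound 1 by trifluoromethyl in place of bromo on an aromatic carbon. Within the data shown here, only the bromo-to-chloro step bears on this change, and it was flat; no measured step covers a trifluoromethyl at this position. The expected step is therefore small, a 1.1-fold lower number from compound 1 to compound 3 (0.03 log units; within the scatter), with no direction beyond the scatter. For compound 3 the estimate in this assay is 15000 nM, with a range from 6000 nM to 40000 nM.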

Compound 3, concentration for 50% growth inhibition: 15000 nM
Compound 3: the middle estimate sits on the measured number at the digits printed, within the range that was stated.
By their numbers in this assay, from the lowest: compounds 3, 1 and 2 (each within the scatter of the next).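

In this assay the change at this aromatic carbon is no longer only a swap of one halogen for another: trifluoromethyl brings four heavy atoms in place of one, yet the steps stay within the scatter, both for bromo (a 1.1-fold lower number from compound 1 to compound 3 (0.03 log units; within the scatter)) and for chloro (a 1.1-fold lower number from compound 2 to compound 3 (0.05 log units; within the scatter)). Compounds 1, 2 and 3 therefore show a flat read-out across all three substituents at this position, and the flatness now covers a group that is not a single atom. No measurement shown here offers an explanation for this flat result.

The compounds shown leave open whether an amine, a carboxylic acid or a longer chain at this position would move the read-out beyond the scatter. They also leave open whether the same changes elsewhere on the shared core would remain as flat.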